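Heteroaryl sulfanyl ketones: benzoxazole to benzothiazole

The source may hold more compounds than are shown below. What is called first, only, known or untested is meant among the compounds shown, and "the series" means these compounds.

Measured compounds, with their values in a functional assay on Jurkat cells (Homo sapiens) for inhibition; on this read-out lower numbers stand for stronger inhibition and higher numbers for weaker inhibition:
compound 1 `CC(C)c1cc(OCC(=O)[C@H](CC(=O)O)NC(=O)[C@@H](NC(=O)COc2cccc3ccccc23)C(C)C)no1` — a limit of the assay, > 200000 nM
compound 2 `CC(C)[C@H](NC(=O)COc1cccc2ccccc12)C(=O)N[C@@H](CC(=O)O)C(=O)CSc1nnc(-c2ccccc2)o1` — 150000 nM
compound 3 `CC(C)[C@H](NC(=O)COc1cccc2ccccc12)C(=O)N[C@@H](CC(=O)O)C(=O)CSc1nc2ccccc2o1` — a limit of the assay, > 200000 nM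

Compound 3 sits at the limit of > 200000 nM in this assay, at which 2 of the 3 values shown sit, so no number is known for it in this assay. Compound 4 `CC(C)[C@H](NC(=O)COc1cccc2ccccc12)C(=O)N[C@@H](CC(=O)O)C(=O)CSc1nc2ccccc2s1` is the next member; its change is 1,3-benzothiazol-2-yl in place of 1,3-benzoxazol-2-yl on a sulfur.

Within the data shown here, the steps bearing on this change are all small or unreadable: an at least 1.3-fold higher number from compound 2 to compound 3 (0.12 log units; that floor lies within the scatter), the only other exchange on the sulfur; an at least 1.3-fold lower number from compound 1 to compound 2 (0.12 log units; that floor lies within the scatter); and a step that the two limits leave unreadable from compound 1 to compound 3. Neither aryl swap on the sulfur nor the exchange of the ether for a sulfanyl group has produced a step beyond the scatter, and two of the three values are limits. Compound 4 is therefore expected to show no step beyond the scatter in this assay, giving an estimated a number no higher from compound 3 to compound 4 (the limit leaves the size open). Compound 4 is expected to give about 200000 nM, within 90000 nM to 450000 nM, most likely reported again only as a limit.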

Compound 4, half-maximal inhibitory concentration: > 200000 nM
Compound 4: only a limit was reported (the forecaster's own chance of this, stated with the estimate: 70%); the middle value lies on the limit itself.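

In this assay compound 4 gives > 200000 nM, a limit of the assay and not a number, so 1,3-benzothiazol-2-yl on the sulfur brings no readable value any more than 1,3-benzoxazol-2-yl did. Among these compounds, the only readable new step, an at least 1.3-fold higher number from compound 2 to compound 4 (0.12 log units; that floor lies within the scatter), stays inside the scatter, and the steps to compound 4 from compound 3 and from compound 1 cannot be read, leaving compound 2 as the only member with a number. The series now rests largely on a single limit: the limit of > 200000 nM in this assay, at which 3 of the 4 values shown sit.

Any difference between the 1,3-benzoxazol-2-yl and 1,3-benzothiazol-2-yl groups stays open, as neither compound 3 nor compound 4 has a number. Also open, from the compounds shown here alone, is whether an amine or a carboxylic acid on the 1,3-benzothiazol-2-yl group would give a value inside the range of this read-out.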